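The compounds below may be only part of what the source reports. "The series", "measured", "known", "first", "only" and "open" are said of these compounds alone.

Among the measured compounds shown here, in a functional assay for activation of Alpha-1A adrenergic receptor (Homo sapiens), read by calcium flux (on this read-out lower numbers stand for an effect already at smaller amounts and higher numbers for an effect only at larger amounts of compound), compound 2 `Cc1nc(-c2ccccc2NCC2=NCCN2)co1` gives 324 nM, the second highest of the three numbers measured so far. Compound 1 `Cc1ncc(-c2ccccc2NCC2=NCCN2)o1` gives 110 nM, and compound 3 `Cc1noc(-c2ccccc2NCC2=NCCN2)n1` gives 661 nM; the steps of a 2.9-fold higher number from compound 1 to compound 2 (0.47 log units; beyond the scatter) and a 2.0-fold higher number from compound 2 to compound 3 (0.31 log units; beyond the scatter) are both modest, as is a 6.0-fold higher number from compound 1 to compound 3 (0.78 log units; beyond the scatter). Compound 4 `c1ccc(-c2ccccc2NCC2=NCCN2)nc1` differs from compound 2 by pyridin-2-yl in place of 2-methyl-1,3-oxazol-4-yl on an aromatic carbon. For the measured compounds named here, every measured step exchanges one five-membered aromatic ring for another, so none of them speaks directly to the entry of a six-membered aromatic ring; they show only that exchanges at this aromatic carbon have moved the number modestly in this assay. Compound 4 is therefore expected to give about 350 nM in this assay, within a range from 100 nM to 1200 nM, an estimated step of a 1.1-fold higher number from compound 2 to compound 4 (0.03 log units; within the scatter) that is not expected to reach far beyond the scatter.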

Compound 4, half-maximal effective concentration: 6.76 nM
Compound 4: middle estimate off by 52-fold (1.71 log units), on the high side; the whole stated range lies above it.
By their numbers in this assay, from the lowest: compound 4; then compound 1; then compound 2; then compound 3.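

In this assay, this aromatic carbon proves far more sensitive than the exchanges among five-membered aromatic rings suggested: pyridin-2-yl gives a large step from each of them (a 48-fold lower number from compound 2 to compound 4 (1.68 log units; beyond the scatter); a 98-fold lower number from compound 3 to compound 4 (1.99 log units; beyond the scatter); a 16-fold lower number from compound 1 to compound 4 (1.21 log units; beyond the scatter)). The direction is the same whichever five-membered ring leaves, so the earlier modest steps did not mark the limit of change at this place. Nothing available accounts for this result. On these data alone, how phenyl or pyridin-3-yl would stand at this carbon remains open. So does whether the ring size or the position of the ring nitrogen carries the step.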